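The source may report more compounds than this note shows. Statements on the series, on what has been measured and on what is new or still open speak of the compounds shown alone.

Measured so far:
Compound 1 `CCCS(=O)(=O)Nc1ccc(F)c(C(=O)c2n[nH]c3ncc(-c4cccc(C)c4)cc23)c1F` — 15%
Compound 2 `CCCS(=O)(=O)Nc1ccc(F)c(C(=O)c2n[nH]c3ncc(-c4ccccc4OC)cc23)c1F` — 1.9%
Compound 3 `CCCS(=O)(=O)Nc1ccc(F)c(C(=O)c2n[nH]c3ncc(-c4cccc(OC)c4)cc23)c1F` — 6.3%

In an assay for binding affinity to dual specificity mitogen-activated protein kinase kinase 4 (Homo sapiens), read by KINOMEscan, tested at 100 nM (a lower number here means a stronger effect, a higher number a weaker effect of the compound at the concentration tested), compound 2 gives the lowest of the three numbers. The step of a number 13.1 percentage points lower from compound 1 to compound 2 (beyond the scatter) lies beyond the scatter, whereas the step of a number 4.4 percentage points higher from compound 2 to compound 3 (within the scatter) lies within it, so compound 2 and compound 3 cannot be told apart, and the step of a number 8.7 percentage points lower from compound 1 to compound 3 (within the scatter) also stays within the scatter. All three numbers are small, meaning a strong effect at the concentration tested.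

Compound 4 `CCCS(=O)(=O)Nc1ccc(F)c(C(=O)c2n[nH]c3ncc(-c4ccc(Cl)c(Cl)c4)cc23)c1F` is not yet measured. It differs from compound 2 by 3,4-dichlorophenyl in place of 2-methoxyphenyl on an aromatic carbon. Within the data shown here, none of the measured steps exchanges a methoxy or methyl group for chlorine, and none puts two substituents on that ring, so no step bears directly on this change. The measured steps only show that moving or swapping a single small group shifts this assay by little, at most modestly, as the step of a number 13.1 percentage points lower from compound 1 to compound 2 (beyond the scatter) shows. Compound 4 is therefore expected to stay in the same low region, with a step of a number 6.1 percentage points higher from compound 2 to compound 4 (within the scatter) expected from compound 2. The estimate for compound 4 is 8%, in a range from 1% to 30%.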

Compound 4, a percentage reported as activity, at one concentration (the size of the read-out at that concentration, not a potency): 45%
Estimate against measurement, compound 4: 37 percentage points below; the whole stated range lies below it.
By their numbers in this assay, from the lowest: compounds 2, 3 and 1 (each within the scatter of the next, the first and the last beyond it); then compound 4.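

In this assay, among these compounds, the group on this aromatic carbon of the shared core proves able to weaken the effect substantially, which the earlier compounds, separated by a modest step at most, had not revealed: the exchange for 3,4-dichlorophenyl gives a number 43.1 percentage points higher from compound 2 to compound 4 (beyond the scatter) and a number 38.7 percentage points higher from compound 3 to compound 4 (beyond the scatter), and the step against the 3-methylphenyl group is a number 30 percentage points higher from compound 1 to compound 4 (beyond the scatter). All three steps run in the same direction and lie beyond the scatter, so compound 4 has the weakest effect of the four at the concentration tested, and the position tolerates 2-methoxyphenyl, 3-methoxyphenyl and 3-methylphenyl far better than 3,4-dichlorophenyl in this read-out. Nothing available explains why the number rises with this change.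

The compounds shown leave open whether a single chlorine would be enough for this rise, as a 3-chlorophenyl or a 4-chlorophenyl group would test, or whether it takes both chlorines together. They also leave open how this position would respond to a 3,4-dimethoxyphenyl group, or to a phenyl ring bearing an amine or a carboxylic acid.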